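This account rests on a few compounds, and the source may have more. Where it says the series, first, only, none or still open, it means among the compounds named here.

Measured so far in a functional assay on HL-60 cells (Homo sapiens) for inhibition, read by MTT assay, with a stated time of 72 h; a lower number here means a stronger inhibitor, a higher number a weaker inhibitor:

- compound 1 `Cc1ccc(-c2nnc(-c3ccc(C)c(C(F)(F)F)c3)o2)cc1Nc1nccc(-c2cccnc2)n1`: compound 1 gives > 30000 nM, a limit of this assay, not a number.
- compound 2 `Cc1ccc(-c2nnc(-c3cccnc3)o2)cc1Nc1nccc(-c2cccnc2)n1`: compound 2 gives > 30000 nM, again a limit.
- compound 3 `Cc1nnc(-c2ccc(C)c(Nc3nccc(-c4cccnc4)n3)c2)o1`: compound 3 gives > 30000 nM, again a limit.

All three values sit at the limit of > 30000 nM in this assay, at which 3 of the 3 values shown sit, so compound 1 stands nowhere in particular within the series: it is indistinguishable from compound 2 and compound 3 on what is shown. The three steps among them, a step that the two limits leave unreadable from compound 1 to compound 2, a step that the two limits leave unreadable from compound 1 to compound 3 and a step that the two limits leave unreadable from compound 2 to compound 3, are therefore unreadable in size and direction; swapping the substituent on the shared core between 4-methyl-3-(trifluoromethyl)phenyl, pyridin-3-yl and methyl produced no value inside the measurable window.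

Compound 4 `Cc1ccc(-c2nnc(-c3ccc(CN4CCN(CCN=C=S)CC4)c(C(F)(F)F)c3)o2)cc1Nc1nccc(-c2cccnc2)n1` differs from compound 1 by a group of 11 heavy atoms (7 carbon, 3 nitrogen, 1 sulfur; one six-membered non-aromatic ring with 2 hetero atoms) in place of a hydrogen atom, on a saturated chain carbon bound to an aromatic carbon. Within the data shown here, none of the measured steps touches this place, and none of them yields a readable size, so no step beyond the scatter can be predicted in either direction. The expectation rests only on compound 1 sitting at > 30000 nM. Compound 4 is therefore expected at 30000 nM, with a range from 5000 nM to 100000 nM. The step this estimate implies is a number no higher from compound 1 to compound 4 (the limit leaves the size open), and a further limit read-out is expected to be the most likely outcome.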

Compound 4, half-maximal inhibitory concentration: 70 nM
The estimate for compound 4 lay 430-fold (2.63 log units) above the measured number, outside the stated range (below it).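

On a saturated chain carbon bound to an aromatic carbon, the group of 11 heavy atoms in place of a hydrogen atom gives an at least 420-fold lower number from compound 1 to compound 4 (2.63 log units; beyond the scatter) in this assay. On these data alone, compound 1 gives > 30000 nM, a limit and not a number, so the full size of this step stays open. This place is the first in the series where a change yields a readable value, while the steps among compound 1, compound 2 and compound 3 cannot be read: the limit of > 30000 nM in this assay, at which 3 of the 4 values shown sit.

The compounds shown do not separate the part played by the six-membered ring from that of the isothiocyanate at the end of the chain; an analogue carrying a primary amine or an acetamide in place of the isothiocyanate would address this. As far as these compounds go, whether the same group gives a readable value on a compound with pyridin-3-yl in place of 4-methyl-3-(trifluoromethyl)phenyl also remains open.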